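Methyl for trifluoromethyl on the amide-side aryl ring

A few compounds are considered here, and "the series" means these few. Any claim that something is new, unique, unknown or untested is made for them only; others in the source may bear on it.

Measured so far:
compound 1 `O=S(=O)(NCCNc1nccc(-c2c(-c3cccc(F)c3)nc3sccn23)n1)c1ccc(C(F)(F)F)cc1`, 8450 nM
compound 2 `O=C(NCCNc1nccc(-c2c(-c3cccc(F)c3)nc3sccn23)n1)c1ccc(C(F)(F)F)cc1`, 9260 nM

In a functional assay on SK-MEL-28 cells (Homo sapiens) for cytotoxicity, read by MTT assay (a higher number here means a weaker inhibitor, a lower number a stronger inhibitor), compound 2 gives 9260 nM, and compound 1 gives 8450 nM; the two numbers lie within the usual scatter of each other, so neither can be called the stronger. Compound 3 `Cc1ccc(C(=O)NCCNc2nccc(-c3c(-c4cccc(F)c4)nc4sccn34)n2)cc1` differs from compound 2 in one place: methyl in place of trifluoromethyl on an aromatic carbon. Going by the values given here, no measured pair shows this change, so no size for it is known here. The expected step from compound 2 to compound 3 in this assay is a 1.3-fold higher number from compound 2 to compound 3 (0.11 log units; within the scatter), a small change. Compound 3 is therefore estimated at 12000 nM, with a range from 5000 nM to 30000 nM.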

Compound 3, half-maximal inhibitory concentration: 18800 nM
Compound 3: the middle estimate sits 1.6-fold (0.19 log units) below what was measured; the range from low to high includes it.
By their numbers in this assay, from the lowest: compounds 1 and 2 (each within the scatter of the next); then compound 3.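

In this assay, going by these compounds alone, the change from 4-(trifluoromethyl)phenyl to 4-methylphenyl gives a 2.0-fold higher number from compound 2 to compound 3 (0.31 log units; beyond the scatter) and so shows that the number responds to the group at this place, which the earlier compounds, differing elsewhere, could not show. This is a modest step resting on a single pair, and nothing measured here accounts for it. Still open, as far as these compounds go, is whether a chlorine atom, a methoxy group or a bare hydrogen at this place would read closer to compound 2 or compound 3, and whether methyl would produce a similar step on the sulfonamide, compound 1.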